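The source may hold more compounds than are shown below. What is called first, only, known or untested is meant among the compounds shown, and "the series" means these compounds.

In a functional assay on MCF7 cells (Homo sapiens) for antiproliferative activity, read by MTT assay, with a stated time of 48 h (a lower number here means a stronger inhibitor, a higher number a weaker inhibitor), compound 1 (`O=C(/C=C/c1cccc(Cl)c1)c1nc2ccccc2s1`) reads > 100000 nM as a limit of the assay and not a number. Compound 2 (`OC(/C=C/c1cccc(Cl)c1)c1nc2ccccc2[nH]1`) also reads > 100000 nM as a limit and not a number. Within the data shown here, compound 3 (`O=C(/C=C/c1ccccn1)c1nc2ccccc2[nH]1`) gives 3640 nM and so holds the only actual number of the three.

Compound 4 (`O=C(/C=C/c1ccncc1)c1nc2ccccc2[nH]1`) has not yet been measured. It differs from compound 3 by a single exchange, pyridin-4-yl in place of pyridin-2-yl on a double-bonded chain carbon bound to a double-bonded chain carbon in all, with pyridin-4-yl in place of pyridin-2-yl on a double-bonded chain carbon bound to a double-bonded chain carbon. The two have the same atoms, joined differently.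

Among the measured compounds shown here, no measured pair differs in one place, so nothing yet shows how large such a step can be. The expectation therefore rests on compound 3 at 3640 nM as its only anchor. The expected step of a 1.6-fold higher number from compound 3 to compound 4 (0.22 log units; within the scatter) is about the size of the scatter, leaning toward a weaker inhibitor. Compound 4 is expected at 6000 nM with an estimated range from 1800 nM to 25000 nM overall.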

Compound 4, half-maximal inhibitory concentration: 20900 nM
Compound 4: middle estimate off by 3.5-fold (0.54 log units), on the low side; the range from low to high includes it.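

In this assay, among these compounds, the exchange of pyridin-2-yl for pyridin-4-yl on a double-bonded chain carbon bound to a double-bonded chain carbon gives a 5.7-fold higher number from compound 3 to compound 4 (0.76 log units; beyond the scatter), the first step whose size can be read. The two compounds have the same atoms, joined differently, so this position responds to where the nitrogen sits within the ring, and not only to which kind of group is present. Compound 4 still gives an actual number, 20900 nM.

Compounds 1 and 2 each stand at a limit of the assay and not a number, and no further step can be read from them: the limit of > 100000 nM in this assay, at which 2 of the 4 values shown sit. From the compounds shown here alone, what a pyridin-3-yl group or a pyridine ring carrying an amine would give at this place stays open. The data do not explain the step.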